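The source may report more compounds than this note shows. Statements on the series, on what has been measured and on what is new or still open speak of the compounds shown alone.

Of the compounds shown here, three sharing one core have been tested in a functional assay on NCI-H460 cells (Homo sapiens) for inhibition, read by sulforhodamine B assay, with a stated time of 48 h; a lower number here means a stronger inhibitor of growth, a higher number a weaker inhibitor of growth. Compound 1 `CC1=CC[C@H](C(C)(C)NC(=S)N/N=C/c2ccc(O)cc2)CC1` gives > 100000 nM there, which is a limit of the assay rather than a number. Compound 3 `CC1=CC[C@H](C(C)(C)NC(=S)N/N=C/c2ccc(F)cc2)CC1` likewise gives > 100000 nM, again a limit. Compound 2 `CC1=CC[C@H](C(C)(C)NC(=S)N/N=C/c2ccc(N(C)C)cc2)CC1` gives 53400 nM. Compound 3 thus stands at the limit where most of the shown values sit (the limit of > 100000 nM in this assay, at which 2 of the 3 values shown sit). Compound 4 `CC1=CC[C@H](C(C)(C)NC(=S)N/N=C/c2ccc[nH]2)CC1` differs from compound 3 by 1H-pyrrol-2-yl in place of 4-fluorophenyl on a carbon with a double bond to nitrogen. The steps touching compound 3, an at least 1.8-fold higher number from compound 2 to compound 3 (0.27 log units; that floor lies within the scatter) and a step that the two limits leave unreadable from compound 1 to compound 3, only swap substituents on the ring and offer scant guidance for replacing the ring itself. Compound 4 is estimated to give 80000 nM in this assay, between 20000 nM and 300000 nM. The expected step is therefore an at least 1.2-fold lower number from compound 3 to compound 4 (0.09 log units; that floor lies within the scatter).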

Compound 4, concentration for 50% growth inhibition: 18000 nM
Compound 4: middle estimate off by 4.4-fold (0.65 log units), on the high side; measured number below the stated range.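

In this assay, exchanging the ring itself gives a step that can be read beyond the scatter, which the substituent swaps on the ring did not: 1H-pyrrol-2-yl in place of 4-fluorophenyl brings an at least 5.5-fold lower number from compound 3 to compound 4 (0.74 log units; beyond the scatter), and in place of 4-hydroxyphenyl it brings an at least 5.5-fold lower number from compound 1 to compound 4 (0.74 log units; beyond the scatter). Both steps are floors, since each starts from a compound whose value is a limit: the limit of > 100000 nM in this assay, at which 2 of the 4 values shown sit. The compounds shown leave open whether the ring's hydrogen-bearing nitrogen matters, or only the change from a six-membered to a five-membered ring. Furan-2-yl, thiophen-2-yl or 1-methyl-1H-pyrrol-2-yl at this place would separate these.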